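A few compounds are considered here, and "the series" means these few. Any claim that something is new, unique, unknown or untested is made for them only; others in the source may bear on it.

In a functional assay on A-431 cells (Homo sapiens) for cytotoxicity, read by MTT assay, with a stated time of 72 h (a higher number here means a weaker inhibitor, a lower number a stronger inhibitor), compound 1 `Cc1cccc(/C(N)=N/NC(=S)N2CCN(c3ccccn3)CC2)n1` gives 19600 nM, the highest of the two numbers recorded so far, while compound 2 `Cc1ccnc(/C(N)=N/NC(=S)N2CCOCC2)c1` gives 6800 nM, a gap beyond the scatter; the two differ in more than one place, so no single change can be read from them. Compound 3 `Cc1ccnc(/C(N)=N/NC(=S)N2CCN(c3ccccn3)CC2)c1` differs from compound 1 in one place only: 4-methylpyridin-2-yl in place of 6-methylpyridin-2-yl on a carbon with a double bond to nitrogen. Among the compounds with values here, with no single-change pair measured, the step of a 1.6-fold lower number from compound 1 to compound 3 (0.21 log units; within the scatter) is expected to be small, towards a lower number, and possibly not beyond the scatter. Compound 3 is therefore estimated at 12000 nM, within a range from 4000 nM to 40000 nM.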

Compound 3, half-maximal inhibitory concentration: 15500 nM
Compound 3: the middle estimate sits 1.3-fold (0.11 log units) below what was measured, within the range that was stated.
By their numbers in this assay, from the lowest: compound 2; then compounds 3 and 1 (each within the scatter of the next).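

In this assay, with 4-methylpyridin-2-yl in place of 6-methylpyridin-2-yl on a carbon with a double bond to nitrogen, the result is a 1.3-fold lower number from compound 1 to compound 3 (0.10 log units; within the scatter) for this first single-change pair. At this place, therefore, the two methylpyridinyl groups cannot be told apart in this assay. No measurement is available to explain this result.

From the compounds shown here alone, what remains open is whether a different group at this place, such as an unsubstituted pyridin-2-yl, a phenyl or a methoxypyridinyl, would shift the number beyond the scatter.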